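This account rests on a few compounds, and the source may have more. Where it says the series, first, only, none or still open, it means among the compounds named here.

Measured compounds in a functional assay on COLO 205 cells (Homo sapiens) for cytotoxicity, read by MTT assay, with a stated time of 24 h; a lower number here means a stronger inhibitor, a higher number a weaker inhibitor:
Compound 1 `CCCCCCCCCCn1cc(Cn2c(C)nc3nc(-c4ccccc4)cc(C(F)(F)F)c3c2=O)nn1` gives 15 ug/mL.
Compound 2 `CCc1nc2nc(-c3ccccc3)cc(C(F)(F)F)c2c(=O)n1Cc1cn(CCC(F)(F)C(F)(F)C(F)(F)C(F)(F)C(F)(F)C(F)(F)C(F)(F)C(F)(F)F)nn1` gives > 200 ug/mL, which is a limit of the assay and not a number.
Compound 3 `CCCCCCCCCCn1cc(Cn2c(CC)nc3nc(-c4ccccc4)cc(C(F)(F)F)c3c2=O)nn1` gives > 200 ug/mL, likewise a limit and not a number.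

Compound 1 and compound 3 share a core and differ by methyl in place of hydrogen on a saturated chain carbon bound to an aromatic carbon. That change gave an at least 13-fold higher number from compound 1 to compound 3 (1.12 log units; beyond the scatter). Compound 2 carries a different core; the difference between the two cores is not broken down here. Compound 4 `CC(C)c1nc2nc(-c3ccccc3)cc(C(F)(F)F)c2c(=O)n1Cc1cn(CCC(F)(F)C(F)(F)C(F)(F)C(F)(F)C(F)(F)C(F)(F)C(F)(F)C(F)(F)F)nn1`, not yet measured, differs from compound 2 by methyl in place of hydrogen on a saturated chain carbon bound to an aromatic carbon and a saturated chain carbon. This is the same kind of change as that from compound 1 to compound 3, but its place is not identical: here the saturated chain carbon is bound to an aromatic carbon and a saturated chain carbon, there only to an aromatic carbon. Two points shape the expectation. First, compound 2 itself sits at the limit of > 200 ug/mL in this assay, at which 2 of the 3 values shown sit. Second, the step from compound 1 to compound 3 was an at least 13-fold higher number from compound 1 to compound 3 (1.12 log units; beyond the scatter), a loss that lengthening the same chain carried. On that basis compound 4 is expected to show a step that the limit leaves unreadable from compound 2 to compound 4 in this assay, and its value is estimated at 300 ug/mL, most likely again only a limit.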

Compound 4, half-maximal inhibitory concentration: > 200 ug/mL
Compound 4 gave a limit, no number; the forecaster's own chance of this, stated with the estimate: 85%; the middle value lies beyond the limit too.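

In this assay, for the compounds shown here, compound 2 and compound 4 each gave only a limit of the assay and not a number, so no step between them can be read. The compounds shown leave open whether going from ethyl to isopropyl on this core changes the result in this assay at all, and by how much.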